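The compounds below may be only part of what the source reports. "The series", "measured", "known", "first", "only" and "open" are said of these compounds alone.

Compound 1 `O=C(OCc1ccccc1)c1ccsc1NC(=O)[C@@H]1CCCN1`: > 250 ug/mL (a limit)
Compound 2 `O=C(Oc1ccccc1)c1ccsc1NC(=O)[C@@H]1CCCN1`: > 250 ug/mL (a limit)

In a toxicity assay on HUVEC cells (Homo sapiens) for inhibition (a lower number here means a stronger inhibitor of growth, a higher number a weaker inhibitor of growth), compound 2 gives > 250 ug/mL, which is a limit and not a number. Compound 3 `O=C(OC1CCCCC1)c1ccsc1NC(=O)[C@@H]1CCCN1` has cyclohexyl in place of phenyl on an oxygen next to a carbonyl group. Among the compounds with values here, the one measured step that bears on this change is a step that the two limits leave unreadable from compound 1 to compound 2, so it offers no size to carry over. The measurements so far stop at the limit of > 250 ug/mL in this assay, at which 2 of the 2 values shown sit. No step beyond the scatter is expected in this assay, and no direction can be favoured. The estimated step is a number no higher from compound 2 to compound 3 (the limit leaves the size open). For compound 3 the expected value is 250 ug/mL, with an estimated range from 120 ug/mL to 500 ug/mL.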

Compound 3, concentration for 50% growth inhibition: 137 ug/mL
The estimate for compound 3 lay 1.8-fold (0.26 log units) above the measured number, and the stated range covers the measured number.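

Cyclohexyl on an oxygen next to a carbonyl group gives the only actual number so far in this assay, since the phenyl and benzyl compounds gave only limits. The change to cyclohexyl reads as an at least 1.8-fold lower number from compound 2 to compound 3 (0.26 log units; that floor lies within the scatter), and the change from benzyl reads as an at least 1.8-fold lower number from compound 1 to compound 3 (0.26 log units; that floor lies within the scatter). The step between compound 1 and compound 2 cannot be read, and the two new steps have no exact size because the earlier values are limits: the limit of > 250 ug/mL in this assay, at which 2 of the 3 values shown sit.

The compounds shown leave open whether an open chain such as hexyl, in place of the cyclohexyl ring, would also give a number in this assay. They also leave open what an amine on that ring would do.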